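A few compounds are considered here, and "the series" means these few. Any claim that something is new, unique, unknown or untested is made for them only; others in the source may bear on it.

Compound 1 `Cn1c(-c2ccc(NC(=O)CSC3=NCCS3)cc2)nc(-c2ccccc2)c1-c1ccccc1`: 18.6%
Compound 2 `CN1CCN(CC(=O)Nc2ccc(-c3nc(-c4ccccc4)c(-c4ccccc4)n3C)cc2)CC1`: 28.6%

In a functional assay on MCF7 cells (Homo sapiens) for cytotoxicity, read by MTT assay, with a stated time of 24 h, tested at 6.4 ug/mL (on this read-out higher numbers stand for a stronger effect at the one concentration tested and lower numbers for a weaker effect), compound 2 gives 28.6% and compound 1 gives 18.6%; the step of a number 10 percentage points higher from compound 1 to compound 2 (within the scatter) is within the scatter, so neither compound stands apart from the other. Compound 3 `Cn1c(-c2ccc(NC(=O)CN3CCN(Cc4ccc(Cl)cc4)CC3)cc2)nc(-c2ccccc2)c1-c1ccccc1` differs from compound 2 by 4-chlorophenyl in place of hydrogen on a saturated chain carbon bound to an amine nitrogen in a ring. Within the data shown here, no measured step touches this place; the only step known, a number 10 percentage points higher from compound 1 to compound 2 (within the scatter), exchanged a whole ring-bearing group without moving beyond the scatter. The step of a number 1.4 percentage points higher from compound 2 to compound 3 (within the scatter) is therefore expected to stay within the scatter. Compound 3 is estimated at 30%, from 15% to 50%.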

Compound 3, a percentage reported as activity, at one concentration (the size of the read-out at that concentration, not a potency): 33.4%
The estimate for compound 3 lay 3.4 percentage points below the measured number, and the stated range covers the measured number.
By their numbers in this assay, from the lowest: compounds 1, 2 and 3 (each within the scatter of the next, the first and the last beyond it).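

In this assay, among these compounds, this is the first look at the saturated chain carbon bound to an amine nitrogen in a ring, and 4-chlorophenyl in place of hydrogen there gives a number 4.8 percentage points higher from compound 2 to compound 3 (within the scatter). Turning methyl into 4-chlorobenzyl, a much larger group, therefore leaves the read-out within the scatter of compound 2. Nothing measured on these compounds offers an explanation for this result. Open, from the compounds shown here alone, is whether plain benzyl, 4-methoxybenzyl or a carboxylic acid at this place would move the read-out beyond the scatter. Going by these compounds, because only one concentration was tested, potency also remains open.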